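Amide-chain change repeated on a hydroxylated core

This account rests on a few compounds, and the source may have more. Where it says the series, first, only, none or still open, it means among the compounds named here.

Measured so far:
compound 1, `CCN(CC)CCCNC(=O)c1ccc(C(CC)(CC)c2ccc(OCC(=O)C(C)(C)C)c(C)c2)n1CC`: 22 nM
compound 2, `C#CCNC(=O)c1ccc(C(CC)(CC)c2ccc(OCC(=O)C(C)(C)C)c(C)c2)n1CC`: 2200 nM
compound 3, `CCN(CC)CCCNC(=O)c1ccc(C(CC)(CC)c2ccc(OCC(O)C(C)(C)C)c(C)c2)n1CC`: 66 nM

In an assay on HL-60 cells for agonist activity at vitamin D3 receptor (Homo sapiens), read by microscopy, with a stated time of 96 h (a lower number here means that less compound is needed, a higher number that more compound is needed for the effect), compound 1 gives 22 nM and is the lowest of the three numbers. The change from compound 1 to compound 2 is ethynyl in place of 2-(diethylamino)ethyl on a saturated chain carbon bound to an amide-type nitrogen, and it made a large step: a 100-fold higher number from compound 1 to compound 2 (2.00 log units; beyond the scatter). The change from compound 1 to compound 3 is 1-hydroxy-2,2-dimethylpropyl in place of (tert-butyl)carbonyl on a saturated chain carbon bound to an oxygen on an aromatic ring, with a modest step: a 3.0-fold higher number from compound 1 to compound 3 (0.48 log units; beyond the scatter). Compound 3 stands second of the three, with compound 2 the furthest from it.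

Compound 4, `C#CCNC(=O)c1ccc(C(CC)(CC)c2ccc(OCC(O)C(C)(C)C)c(C)c2)n1CC`, is not yet measured. It differs from compound 3 by ethynyl in place of 2-(diethylamino)ethyl on a saturated chain carbon bound to an amide-type nitrogen, the same change that was made from compound 1 to compound 2, at the same place; the two cores on which it is made differ by 1-hydroxy-2,2-dimethylpropyl in place of (tert-butyl)carbonyl on a saturated chain carbon bound to an oxygen on an aromatic ring. With one earlier reading of this change, and only that one, the expectation for compound 4 rests on it alone: compound 4 is expected to be well above compound 3, because the same change gave a 100-fold higher number from compound 1 to compound 2 (2.00 log units; beyond the scatter). The step from compound 3 to compound 4 in this assay is estimated at a 100-fold higher number from compound 3 to compound 4 (2.00 log units; beyond the scatter). Whether the second core carries the change to the same extent is not known from these three compounds, so the range is kept wide. The estimate for compound 4 in this assay is 6600 nM, between 1500 nM and 30000 nM.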

Compound 4, half-maximal effective concentration: 240 nM
Compound 4: middle estimate off by 28-fold (1.44 log units), on the high side; measured number below the stated range.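

In this assay, ethynyl in place of 2-(diethylamino)ethyl on the core carrying the 1-hydroxy-2,2-dimethylpropyl group gave a 3.6-fold higher number from compound 3 to compound 4 (0.56 log units; beyond the scatter), so the change raised the number on both cores but did not carry its size from one core to the other: the same change on two cores in this assay, a 100-fold higher number (2.00 log units; beyond the scatter) from compound 1 to compound 2 and a 3.6-fold higher number (0.56 log units; beyond the scatter) from compound 3 to compound 4, 28-fold (1.44 log units) apart, beyond the scatter of two such steps

Read the other way round, 1-hydroxy-2,2-dimethylpropyl in place of (tert-butyl)carbonyl gave a 9.2-fold lower number from compound 2 to compound 4 (0.96 log units; beyond the scatter), so this second change even reversed its direction between the two amide chains: the same change on two cores in this assay, a 3.0-fold higher number (0.48 log units; beyond the scatter) from compound 1 to compound 3 and a 9.2-fold lower number (0.96 log units; beyond the scatter) from compound 2 to compound 4, 28-fold (1.44 log units) apart, beyond the scatter of two such steps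

The two changes therefore do not act independently in these four compounds, and a step measured on one core was a poor guide to the same step on the other, but the data do not show why they depend on each other, nor whether this holds anywhere beyond this single set of four compounds.

On these data alone, it remains open whether other amide chains, such as a plain propyl chain or a longer chain ending in a different amine, would depend on the core in the same way. As far as these compounds go, it is also open whether other groups at the place of the (tert-butyl)carbonyl, such as an ether or a carboxylic acid, would show the same reversal.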